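Trimming a Methoxy Group: From Compound 3 to Compound 4

The source may report more compounds than this note shows. Statements on the series, on what has been measured and on what is new or still open speak of the compounds shown alone.

Compound 1, `Nc1cc(N)c2nc(-c3ccccc3)c(Oc3ccc(F)cc3)nc2c1`: 89100 nM
Compound 2, `COc1cc(CNc2nc3cc(N)cc(N)c3nc2-c2ccccc2)cc(OC)c1OC`: < 50200 nM
Compound 3, `COc1ccc(CNc2nc3cc(N)cc(N)c3nc2-c2ccccc2)cc1OC`: < 100000 nM

Of the compounds shown here, three have been measured in a functional assay on A549 cells (Homo sapiens) for inhibition, read by sulforhodamine B assay, with a stated time of 48 h; a higher number here means that more compound is tolerated, a lower number that less compound is tolerated. Compound 1 gives a numerical value. For compound 2 the result the limit of < 50200 nM in this assay, at which 1 of the 3 values shown sits, is only a limit of the measurement. For compound 3 the result the limit of < 100000 nM in this assay, at which 1 of the 3 values shown sits, is likewise only a limit, so compound 3 stands on no firm number. Going by the values given here, the one step between measured compounds, a step that the two limits leave unreadable from compound 2 to compound 3, is therefore unreadable in size. Compound 4, `COc1ccc(CNc2nc3cc(N)cc(N)c3nc2-c2ccccc2)cc1`, differs from compound 3 by hydrogen in place of methoxy on an aromatic carbon. Among the compounds with values here, no measured step bears on this change, so no direction beyond the scatter is expected; the step that the limit leaves unreadable from compound 3 to compound 4 is an estimate. Compound 4 is expected to give 50000 nM, within the range 10000 nM to 100000 nM.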

Compound 4, concentration lethal to 50% of the cells: < 100000 nM
Compound 4 ended at the assay's limit; the forecaster's own chance of this, stated with the estimate: 40%; the middle value does not contradict the limit.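

In this assay, going by these compounds alone, compound 4 gives < 100000 nM, which is only a limit, as is the result for compound 3, so no step between them can be read. The compounds shown leave open whether hydrogen in place of methoxy changes the result at all, and in which direction.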